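This account rests on a few compounds, and the source may have more. Where it says the series, first, only, none or still open, it means among the compounds named here.

Measured so far:
Compound 1, `CC(C)[C@H](C[C@H]1OC(=O)NC1=O)c1ccc(-c2ccc3cccc(F)c3c2)[nH]c1=O`: 35400 nM
Compound 2, `CC(C)C(c1ccc(-c2ccc3cccc(F)c3c2)[nH]c1=O)C1C(=O)NC(=O)N1C`: 17900 nM

Both numbers come from a physicochemical assay for solubility, in phosphate buffer, measured as kinetic solubility; on this read-out lower numbers stand for lower solubility and higher numbers for higher solubility. In this assay compound 1 gives 35400 nM, and compound 2 gives 17900 nM; the gap between the two lies within the usual scatter of repeated measurements, so neither compound can be said to dissolve better than the other. For the measured compounds named here, compound 2 therefore stands level with the only other measured compound, with no separation the assay could support.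

Compound 3, `CC(C)C(/C=C1/C(=O)NC(=O)N1C)c1ccc(-c2ccc3cccc(F)c3c2)[nH]c1=O`, has not yet been measured. It differs from compound 2 in one place: a group of 9 heavy atoms (5 carbon, 2 nitrogen, 2 oxygen; one five-membered non-aromatic ring with 2 hetero atoms) in place of a group of 8 heavy atoms (4 carbon, 2 nitrogen, 2 oxygen; one five-membered non-aromatic ring with 2 hetero atoms), on a saturated chain carbon bound to an aromatic carbon and a saturated chain carbon. The rest of the structure is shared unchanged.

Going by the values given here, no pair of measured compounds differing in one place is available, so no measured step exists to guide the expectation for this change. For compound 3 the expected step is a 1.5-fold lower number from compound 2 to compound 3 (0.17 log units; within the scatter), small, toward lower solubility, and possibly no larger than the scatter. Compound 3 is estimated at 12000 nM, with a range from 5000 nM to 30000 nM.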

Compound 3, solubility: 34800 nM
Estimate against measurement, compound 3: 2.9-fold (0.46 log units) below, and the stated range ends below it.
By their numbers in this assay, from the lowest: compounds 2, 3 and 1 (each within the scatter of the next).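

At the saturated chain carbon bound to an aromatic carbon and a saturated chain carbon, this assay now provides a first measured one-place step: replacing the 3-methyl-2,5-dioxoimidazolidin-4-yl group with the group of 9 heavy atoms and 3 double bonds outside aromatic rings gives a 1.9-fold higher number from compound 2 to compound 3 (0.29 log units; within the scatter) in this read-out. The two numbers therefore cannot be separated, so this single pair shows no measurable difference for this change, something the earlier unpaired compounds could not address. No measured evidence is available to explain this result.

This one pair leaves open whether a different group at the same place, such as an amine or a carboxylic acid, would give a step beyond the scatter. For the compounds shown here, it also leaves open whether the same replacement would give a similarly small step on a core other than the one shared by compound 2 and compound 3, or in a read-out other than this assay.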